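Fluoro in Place of Trifluoromethyl on the Aryl Arm

The source may hold more compounds than are shown below. What is called first, only, known or untested is meant among the compounds shown, and "the series" means these compounds.

Compound 2 `C=CCn1c(=O)/c(=C\c2ccccc2C(F)(F)F)[nH]c(=O)/c1=C\c1ccccc1OC` gives 4600 nM in a functional assay on HeLa cells (Homo sapiens) for cytotoxicity, read by CCK-8 assay, with a stated time of 72 h (on this read-out lower numbers stand for stronger inhibition and higher numbers for weaker inhibition), and stands highest of the two numbers recorded so far; its nearest neighbour is compound 1 `C=CCn1c(=O)/c(=C\c2cccc(Cl)c2Cl)[nH]c(=O)/c1=C\c1ccccc1OC`, which in this assay gives 1600 nM. Within the data shown here, the single measured step, a 2.9-fold higher number from compound 1 to compound 2 (0.46 log units; beyond the scatter), shows that swapping one substituted aryl group for another on the double-bonded chain carbon moves the number only modestly. Compound 3 `C=CCn1c(=O)/c(=C\c2ccccc2F)[nH]c(=O)/c1=C\c1ccccc1OC` differs from compound 2 by fluoro in place of trifluoromethyl on an aromatic carbon. Among the measured compounds shown here, no measured step exchanges trifluoromethyl for fluoro, so the one step available bears on this change only loosely, through the aryl group it varies. A modest shift in this assay is therefore expected rather than a large one, with the direction uncertain; the step of a 1.5-fold lower number from compound 2 to compound 3 (0.19 log units; within the scatter) is estimated. For compound 3 in this assay the estimate is 3000 nM, with a range from 1000 nM to 9000 nM.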

Compound 3, half-maximal inhibitory concentration: 45000 nM
The estimate for compound 3 lay 15-fold (1.18 log units) below the measured number; the measured number lies above the stated range.
By their numbers in this assay, from the lowest: compound 1; then compound 2; then compound 3.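

In this assay, fluoro in place of trifluoromethyl on this aromatic carbon, ortho to a large group, gives a 9.8-fold higher number from compound 2 to compound 3 (0.99 log units; beyond the scatter) and so shows that this change moves the number more than the earlier swap of aryl groups did. Among these compounds, measured against the 2,3-dichlorophenyl arm, the 2-fluorophenyl arm gives a 28-fold higher number from compound 1 to compound 3 (1.45 log units; beyond the scatter) and is the only step here graded large, so the three arms now fall in the order 2,3-dichlorophenyl, 2-(trifluoromethyl)phenyl, 2-fluorophenyl, from lowest number to highest. Nothing measured here explains why the number rises with fluoro.

The compounds shown leave open how a chloro, a methyl or an amine on the same aromatic carbon would compare. They also leave open whether this order would hold with a different group on the other aryl arm.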